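A few compounds are considered here, and "the series" means these few. Any claim that something is new, unique, unknown or untested is made for them only; others in the source may bear on it.

Working notes on the series. Compound 1 `O=C(/N=C1\NC2(CCCCO2)CCS1)c1ccc(Br)cc1` carries a 4-bromophenyl on the carbonyl carbon. In a functional assay on the whole organism (strain CF-1) with Mus musculus as the target, in the writhing test, with a stated time of 15 min (on this read-out higher numbers stand for an effect only at larger amounts of compound and lower numbers for an effect already at smaller amounts), compound 1 reports only a limit, > 200 mg/kg. Among the compounds with values here, compound 2 `CC(C)(C)C(=O)/N=C1\NC2(CCCCO2)CCS1` carries a tert-butyl in the same place, and in this assay compound 2 gives 200 mg/kg; this is the only number in the set. The step of a number no higher from compound 1 to compound 2 (the limit leaves the size open) is therefore of unreadable size, which rests on (the limit of > 200 mg/kg in this assay, at which 1 of the 2 values shown sits).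

Compound 3 `CC1(C(=O)/N=C2\NC3(CCCCO3)CCS2)CCCCC1` is not yet measured. The change is 1-methylcyclohexyl in place of tert-butyl on a carbonyl carbon. Within the data shown here, the single measured step sits on the same carbonyl carbon but does not yield a size, so no direction beyond the scatter is expected: the step from compound 2 to compound 3 is estimated as no change at the digits printed from compound 2 to compound 3 (within the scatter). In this assay compound 3 is expected at 200 mg/kg, with a range from 100 mg/kg to 400 mg/kg.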

Compound 3, dose for half-maximal effect: > 200 mg/kg
Compound 3 ended at the assay's limit; the forecaster's own chance of this, stated with the estimate: 50%; the middle value lies on the limit itself.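

Within the data shown here, with 1-methylcyclohexyl on the carbonyl carbon, compound 3 stands at a limit in this assay, as compound 1 does, so tert-butyl in compound 2 remains the only group at this position with an actual number. Enlarging the tert-butyl to 1-methylcyclohexyl gives a number no lower from compound 2 to compound 3 (the limit leaves the size open). The size of this step and of the other steps among these compounds cannot be read: the limit of > 200 mg/kg in this assay, at which 2 of the 3 values shown sit.

The compounds shown leave open whether any group at this position gives a number lower than that of compound 2, 200 mg/kg. A smaller group such as methyl or cyclopropyl, or a chain carrying an amine, would show whether the read-out can move away from this limit at all.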